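Pyridyl in place of phenyl on the pyrazole carboxylic acid series

The source may report more compounds than this note shows. Statements on the series, on what has been measured and on what is new or still open speak of the compounds shown alone.

Three compounds sharing one core have been run in a functional assay on BJAB cells (Homo sapiens) for antiproliferative activity, with a stated time of 4 days; a higher number here means that more compound is needed for the effect, a lower number that less compound is needed. Compound 1 `COc1ccc(-c2c(C)nn(-c3nc(-c4ccc(Cl)c(Cl)c4)c(SC(C)C)s3)c2C(=O)O)cc1` gives 2100 nM. Compound 2 `COc1cncc(-c2c(C)nn(-c3nc(-c4ccc(Cl)c(Cl)c4)c(SC(C)C)s3)c2C(=O)O)c1` gives 21000 nM. Compound 3 `Cc1nn(-c2nc(-c3ccc(Cl)c(Cl)c3)c(SC(C)C)s2)c(C(=O)O)c1-c1ccc(Cl)cc1` gives 2500 nM, which places it second highest of the three numbers; its nearest neighbour is compound 1, within the scatter, and its furthest is compound 2.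

The next compound, compound 4 `CNc1cc(-c2c(C)nn(-c3nc(-c4ccc(Cl)c(Cl)c4)c(SC(C)C)s3)c2C(=O)O)ccn1`, is not yet measured. Its change from compound 3 is 2-(methylamino)pyridin-4-yl in place of 4-chlorophenyl on an aromatic carbon.

Going by the values given here, two measured steps bear on this change. The swap of a phenyl for a pyridyl ring gave a 10-fold higher number from compound 1 to compound 2 (1.00 log units; beyond the scatter), and the reverse direction gave an 8.4-fold lower number from compound 2 to compound 3 (0.92 log units; beyond the scatter). The exchange of substituents on the phenyl ring itself gave a 1.2-fold higher number from compound 1 to compound 3 (0.08 log units; within the scatter), which is within the scatter. On these data alone, the move to compound 4 again replaces a carbon-only six-membered ring with a pyridyl ring, so a higher number beyond the scatter in this assay is expected, though the 2-(methylamino) substituent differs from the 5-methoxy of compound 2 and the weight of that is unknown.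

For compound 4 the expected step is a 4.8-fold higher number from compound 3 to compound 4 (0.68 log units; beyond the scatter), giving an estimate of 12000 nM with a range from 3000 nM to 40000 nM.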

Compound 4, half-maximal effective concentration: 18000 nM
For compound 4 the middle estimate is 1.5-fold (0.18 log units) below the measured one, and the stated range covers the measured number.
By their numbers in this assay, from the lowest: compounds 1 and 3 (each within the scatter of the next); then compounds 4 and 2 (each within the scatter of the next).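

In this assay, a second pyridyl group at this position, on an aromatic carbon next to the ring atom that bears a carboxy group, also gives a number on the high side, both against the 4-chlorophenyl group (a 7.2-fold higher number from compound 3 to compound 4 (0.86 log units; beyond the scatter)) and against the 4-methoxyphenyl group (an 8.6-fold higher number from compound 1 to compound 4 (0.93 log units; beyond the scatter)). The shift seen with compound 2 is therefore not confined to the 5-methoxypyridin-3-yl group, and among the four compounds shown, none goes against the split between the two pyridyl compounds and the two with a carbon-only ring. The two pyridyl groups differ in where the ring is attached and in what they carry, yet their numbers cannot be told apart (a 1.2-fold lower number from compound 2 to compound 4 (0.07 log units; within the scatter)), and nothing shown explains the rise with either group.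

The compounds shown leave open whether the higher number follows the ring nitrogen or the substituents, since no pair carries the same substituent on both a phenyl and a pyridyl ring. An unsubstituted pyridyl ring and a phenyl ring carrying a methylamino group would bear directly on that question.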